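Swapping the terminal amine on a flexible side chain

The source may report more compounds than this note shows. Statements on the series, on what has been measured and on what is new or still open speak of the compounds shown alone.

compound 1 `CCN(CC)CCCCOc1c(OC)cc2oc(-c3ccccc3)cc(=O)c2c1O`: 17400 nM
compound 2 `CN1CCN(CCCCOc2c(O)cc3oc(-c4ccccc4)cc(=O)c3c2O)CC1`: 82900 nM

In a functional assay on BCG823 cells (Homo sapiens) for antiproliferative activity, read by MTT assay, with a stated time of 48 h (a lower number here means a stronger inhibitor, a higher number a weaker inhibitor), compound 1 gives 17400 nM, the lowest of the two numbers, and compound 2 gives 82900 nM, a gap beyond the usual scatter. Compound 3 `COc1cc2oc(-c3ccccc3)cc(=O)c2c(O)c1OCCCCN1CCCC1` differs from compound 1 in one place: pyrrolidin-1-yl in place of diethylamino on a saturated chain carbon, four bonds along the chain from an oxygen on an aromatic ring. Within the data shown here, no pair of measured compounds differs by this change alone, so nothing measured fixes its size. The two groups match in what is counted. The expected step is a 1.2-fold lower number from compound 1 to compound 3 (0.06 log units; within the scatter), nothing beyond the scatter. Compound 3 is therefore expected to give 15000 nM, with a range from 6000 nM to 40000 nM.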

Compound 3, half-maximal inhibitory concentration: 10600 nM
For compound 3 the middle estimate is 1.4-fold (0.15 log units) above the measured one; measured number inside the range.
By their numbers in this assay, from the lowest: compounds 3 and 1 (each within the scatter of the next); then compound 2.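

In this assay, pyrrolidin-1-yl in place of diethylamino on this saturated chain carbon gives a 1.6-fold lower number from compound 1 to compound 3 (0.22 log units; within the scatter), so at this position the open amine and the ring amine, which match in what is counted, are not told apart. Compound 2 differs from compound 1 in more than one place and does not bear on this step. No measurement at hand gives a cause for the result. The compounds shown leave open whether piperidin-1-yl or morpholin-4-yl at this carbon, or a longer chain carrying pyrrolidin-1-yl, would move the number beyond the scatter.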